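This account rests on a few compounds, and the source may have more. Where it says the series, first, only, none or still open, it means among the compounds named here.

Measured so far:
Compound 1, `C=C(C)c1ccccc1OC(C)C1=NCCN1`: 115 nM in a functional assay on CHO cells for agonist activity at Alpha-2C adrenergic receptor (Homo sapiens); a higher number here means that more compound is needed for the effect, a lower number that less compound is needed
Compound 2, `CCOc1ccccc1OC(C)C1=NCCN1`: 10000 nM in this assay

Of these two numbers in this assay, compound 1 stands lowest. Within the data shown here, the single measured step runs in one direction: an 87-fold higher number from compound 1 to compound 2 (1.94 log units; beyond the scatter), when ethoxy replaced 1-methylethenyl on an aromatic carbon. Compound 3, `CC(Oc1ccccc1C=O)C1=NCCN1`, carries another exchange on an aromatic carbon: formyl in place of 1-methylethenyl on an aromatic carbon. Because of an 87-fold higher number from compound 1 to compound 2 (1.94 log units; beyond the scatter), removing 1-methylethenyl is expected to raise the number for compound 3 as well, though nothing measured shows how far formyl goes. The expected step is a 17-fold higher number from compound 1 to compound 3 (1.24 log units; beyond the scatter). Compound 3 is estimated at 2000 nM, within 300 nM to 10000 nM.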

Compound 3, half-maximal effective concentration: 100 nM
Compound 3: the middle estimate sits 20-fold (1.30 log units) above what was measured; measured number outside the range, below it.
By their numbers in this assay, from the lowest: compounds 3 and 1 (each within the scatter of the next); then compound 2.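

Removing 1-methylethenyl from this aromatic carbon need not weaken the effect in this assay: formyl in its place gives a 1.2-fold lower number from compound 1 to compound 3 (0.06 log units; within the scatter) and leaves the two groups indistinguishable. The high number therefore belongs to ethoxy rather than to the loss of 1-methylethenyl, as formyl in place of ethoxy gives a 100-fold lower number from compound 2 to compound 3 (2.00 log units; beyond the scatter) and shows. No outside measurement explains why these groups differ. From the compounds shown here alone, it remains open whether other groups on this carbon, such as an amine, a carboxylic acid or a longer chain, would match compound 1 and compound 3 or instead compound 2.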